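From Compound 3 to Compound 4 at the Assay Limit

The source may report more compounds than this note shows. Statements on the series, on what has been measured and on what is new or still open speak of the compounds shown alone.

Measured in a functional assay on SMMC-7721 cells (Homo sapiens) for antiproliferative activity, read by MTT assay, with a stated time of 48 h; a higher number here means a weaker inhibitor, a lower number a stronger inhibitor
Compound 1 `Cn1cc(C2=C(c3nn(CCCn4ccnc4)c4ncccc34)C(=O)NC2=O)c2ccccc21` gives > 100000 nM as a limit
Compound 2 `CN(C)CCCn1nc(C2=C(c3cn(C)c4ccccc34)C(=O)N(c3ccccc3)C2=O)c2cccnc21` gives 31200 nM as a number
Compound 3 `CN(C)CCCn1nc(C2=C(c3cn(C)c4ccccc34)C(=O)NC2=O)c2cccnc21` gives > 100000 nM as a limit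

Compound 3 has only a limit (> 100000 nM) in this assay and no number. The change to compound 4 `Cn1cc(C2=C(c3nn(CCn4ccnc4)c4ncccc34)C(=O)NC2=O)c2ccccc21` is 1H-imidazol-1-yl in place of (dimethylamino)methyl on a saturated chain carbon, two bonds along the chain from an aromatic nitrogen and it places 1H-imidazol-1-yl in place of (dimethylamino)methyl on a saturated chain carbon, two bonds along the chain from an aromatic nitrogen.

The closest measured evidence is a step that the two limits leave unreadable from compound 1 to compound 3 for dimethylamino in place of 1H-imidazol-1-yl on the chain, and it gives no size to carry over. For the measured compounds named here, the one readable step is an at least 3.2-fold higher number from compound 2 to compound 3 (0.50 log units; beyond the scatter) for hydrogen in place of phenyl on an amide-type nitrogen in a ring, a place where compound 4 keeps the hydrogen of compound 3. Compound 1 and compound 3 both carry that hydrogen and share the limit of > 100000 nM in this assay, at which 2 of the 3 values shown sit, with no number for either.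

No step beyond the scatter is therefore expected from the chain change, and a further limit is the likeliest report. The expected step is a number no higher from compound 3 to compound 4 (the limit leaves the size open) and it remains an estimate. For compound 4 the estimated value is 100000 nM (expected range 35000 nM to 250000 nM).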

Compound 4, half-maximal inhibitory concentration: > 100000 nM
Compound 4 ended at the assay's limit (the forecaster's own chance of this, stated with the estimate: 75%); the middle value sits exactly at the limit.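

Neither the step from compound 3 to compound 4 nor the step from compound 1 to compound 4 can be read, as all three compounds stop at one shared limit: the limit of > 100000 nM in this assay, at which 3 of the 4 values shown sit. The compounds shown leave open what size of step, if any, 1H-imidazol-1-yl in place of (dimethylamino)methyl gives on the chain, and whether chain length matters where the amide hydrogen is kept.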